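Aryl swap on the enone chain: working notes

A few compounds are considered here, and "the series" means these few. Any claim that something is new, unique, unknown or untested is made for them only; others in the source may bear on it.

Measured so far:
compound 1 `COc1ccc(/C=C/C(=O)c2ccccc2NC(=O)NS(=O)(=O)c2ccc(C)cc2)c(OC)c1` — 16 ug/mL
compound 2 `Cc1ccc(S(=O)(=O)NC(=O)Nc2ccccc2C(=O)/C=C/c2cccc(O)c2)cc1` — 39.3 ug/mL

In an ADME assay on the whole organism for cytotoxicity, with Artemia salina as the target, with a stated time of 24 h (on this read-out higher numbers stand for an effect only at larger amounts of compound and lower numbers for an effect already at smaller amounts), compound 2 gives 39.3 ug/mL, the highest of the two numbers; the nearest is compound 1 with 16 ug/mL, and the step of a 2.5-fold higher number from compound 1 to compound 2 (0.39 log units; beyond the scatter) is the only one recorded. Compound 3 `Cc1ccc(S(=O)(=O)NC(=O)Nc2ccccc2C(=O)/C=C/c2ccccc2[N+](=O)[O-])cc1` takes the next step: 2-nitrophenyl in place of 3-hydroxyphenyl on a double-bonded chain carbon bound to a double-bonded chain carbon. Among the measured compounds shown here, the earlier aryl swap at this same chain carbon moved the read-out modestly, so another modest shift is expected here, with the direction uncertain given only one prior step. The expected step from compound 2 to compound 3 is a 1.3-fold lower number from compound 2 to compound 3 (0.12 log units; within the scatter). Compound 3 is estimated at 30 ug/mL, within 12 ug/mL to 80 ug/mL.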

Compound 3, concentration for half-maximal effect: 40.1 ug/mL
For compound 3 the middle estimate is 1.3-fold (0.13 log units) below the measured one; low and high end bracket the measured number.
By their numbers in this assay, from the lowest: compound 1; then compounds 2 and 3 (each within the scatter of the next).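

In this assay, 2-nitrophenyl in place of 3-hydroxyphenyl at this chain carbon gives a 1.0-fold higher number from compound 2 to compound 3 (0.01 log units; within the scatter) and so leaves these two differently substituted aryl groups unseparated. Compound 1 stands apart from both, with a 2.5-fold higher number from compound 1 to compound 3 (0.40 log units; beyond the scatter) matching the earlier step in size, and 2,4-dimethoxyphenyl alone gives the lower number among these three. Nothing available explains this difference. As far as these compounds go, whether unsubstituted phenyl or an aryl ring carrying an amine at this carbon would read with compound 1 or with compounds 2 and 3 stays open. From the compounds shown here alone, whether a single methoxy group suffices to give the lower number also stays open.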